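Demethylation steps in a benzofuran-free-named ketone series

This account rests on a few compounds, and the source may have more. Where it says the series, first, only, none or still open, it means among the compounds named here.

Compound 1 `CCc1cc2cc(OC)cc(C(=O)c3ccc(OC)cc3)c2o1` carries two methyl groups on oxygen, one on the shared core and one on the benzoyl-attached ring. In an assay for inhibition of solute carrier family 22 member 12 (Homo sapiens), read by scintillation counting, with a stated time of 60 min, tested at 50 uM (on this read-out lower numbers stand for less inhibition and higher numbers for more inhibition at the one concentration tested (going by the name of the read-out)), compound 1 gives 5.2%, the lowest of the two numbers recorded so far. Compound 2 `CCc1cc2cc(OC)cc(C(=O)c3ccc(O)cc3)c2o1` differs from compound 1 in one place, and in this assay compound 2 gives 60%. The step of a number 54.8 percentage points higher from compound 1 to compound 2 (beyond the scatter) therefore shows a large gain on removing the methyl from the oxygen on the benzoyl-attached ring.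

Compound 3 `CCc1cc2cc(O)cc(C(=O)c3ccc(OC)cc3)c2o1` is the other demethylated partner of compound 1. The change is hydrogen in place of methyl on an oxygen on an aromatic ring, this time on the oxygen of the shared core. Among the measured compounds shown here, no measured step covers this position; the only step that bears on the change in kind is the one from compound 1 to compound 2, which was large. The same kind of change at a different place is expected to move the number in the same direction, though with less certainty about its size, so a moderate to large rise in this assay is expected, written as a number 29.8 percentage points higher from compound 1 to compound 3 (beyond the scatter). For compound 3 the estimate in this assay is 35%, with a range from 5% to 70%.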

Compound 3, a percentage reported as inhibition, at one concentration (the size of the read-out at that concentration, not a potency): 9.3%
Estimate against measurement, compound 3: 25.7 percentage points above; the measured number falls inside the stated range.
By their numbers in this assay, from the lowest: compounds 1 and 3 (each within the scatter of the next); then compound 2.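

Methoxy to hydroxy on the oxygen of the shared core gives a number 4.1 percentage points higher from compound 1 to compound 3 (within the scatter) in this assay, so at this position the change leaves the read-out within the scatter of compound 1. The same kind of change at the other oxygen gives a number 54.8 percentage points higher from compound 1 to compound 2 (beyond the scatter) and lies beyond the scatter, which means that in this pair of steps the outcome depends on which oxygen carries the hydrogen, something a single step could not show. Nothing available here accounts for this difference between the two positions.

Open, from the compounds shown here alone, is how a compound with hydroxy on both oxygens would read in this assay, and whether the free hydroxy on the shared core would matter once the other oxygen also carries a hydrogen. Also open, going by these compounds, is how the read-out would respond to a carboxylic acid or an amine in place of either oxygen substituent, or to a longer chain in place of the ethyl group on the shared core.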